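Rearranging the Aryl Group on a Sulfonamide Nitrogen

The compounds below may be only part of what the source reports. "The series", "measured", "known", "first", "only" and "open" are said of these compounds alone.

Measured so far:
compound 1, `CCc1ccccc1NS(=O)(=O)c1ccc(N2CCNC2=O)cc1`: 240 nM
compound 2, `COc1ccc(NS(=O)(=O)c2ccc(N3CCNC3=O)cc2)cc1OC`: 520 nM

Both compounds were tested in a functional assay on HT-29 cells (Homo sapiens) for antiproliferative activity, read by sulforhodamine B assay, with a stated time of 48 h; on this read-out higher numbers stand for weaker inhibition and lower numbers for stronger inhibition. In this assay compound 1 gives 240 nM, the lowest of the two numbers; compound 2 gives 520 nM, and the gap between them lies beyond the usual scatter. Compound 3, `Cc1ccc(C)c(NS(=O)(=O)c2ccc(N3CCNC3=O)cc2)c1`, has not yet been measured. It differs from compound 1 in one place: 2,5-dimethylphenyl in place of 2-ethylphenyl on a sulfonamide nitrogen. The two compounds have the same atoms, joined differently, so the change is a modest rearrangement rather than an addition or removal. Among the measured compounds shown here, no measured pair shows what such a rearrangement does in this assay, so the size of the step remains uncertain. The step of a 1.3-fold higher number from compound 1 to compound 3 (0.10 log units; within the scatter) is expected to be small, probably within the scatter, with a slight lean toward a higher number. Compound 3 is therefore estimated at 300 nM, with a range from 120 nM to 800 nM.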

Compound 3, half-maximal inhibitory concentration: 46 nM
Compound 3: middle estimate off by 6.5-fold (0.81 log units), on the high side; the measured number lies below the stated range.
By their numbers in this assay, from the lowest: compound 3; then compound 1; then compound 2.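

On the sulfonamide nitrogen, replacing 2-ethylphenyl with 2,5-dimethylphenyl changes neither the atoms nor the counts of ring, donors and acceptors, yet in this assay it gives a 5.2-fold lower number from compound 1 to compound 3 (0.72 log units; beyond the scatter). The earlier compounds shown here offered no step at this position, and this one shows that activity here can depend clearly on how the same carbon atoms are arranged on the aryl ring, not only on which atoms are present. No measurement at hand explains why this rearrangement has such an effect.

On these data alone, it remains open whether the step depends on both methyl groups of the 2,5-dimethylphenyl group or on just one of them. How a longer chain such as propyl, or a chlorine atom, would fare on this ring is also unknown.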